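This account rests on a few compounds, and the source may have more. Where it says the series, first, only, none or still open, it means among the compounds named here.

In a functional assay on A2780 cells (Homo sapiens) for inhibition, read by trypan blue exclusion, with a stated time of 72 h (on this read-out higher numbers stand for weaker inhibition of growth and lower numbers for stronger inhibition of growth), compound 2 `CCCn1c(-c2ccc(O)c(O)c2)c(C)c2cc(O)ccc21` gives 8400 nM. Among the three measured compounds it stands second highest. Compound 1 `CCCn1c(-c2ccc(O)cc2)c(C)c2cc(O)ccc21` gives 2300 nM in this assay, and compound 3 `Cc1ncsc1C(=O)Oc1ccc(-c2[nH]c3ccccc3c2C)cc1` gives 13000 nM, a number within the scatter of compound 2. Going by the values given here, the only step between measured compounds that differ in one place is a 3.7-fold higher number from compound 1 to compound 2 (0.56 log units; beyond the scatter), a hydroxy in place of hydrogen on an aromatic carbon.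

Compound 4 `Cc1c(-c2ccc(O)c(O)c2)n(CCCCOc2ccccc2)c2ccc(O)cc12` differs from compound 2 by phenoxymethyl in place of hydrogen on a saturated chain carbon, three bonds along the chain from an aromatic nitrogen. Among the compounds with values here, none of the measured steps touches the chain on the aromatic nitrogen: the one step that is known concerns a hydroxy on an aromatic carbon and so does not bear on this change. Compound 1 and compound 3 carry different chains on the nitrogen, but they also differ from each other in several other places, so their values do not isolate the chain. There is therefore nothing in the measured data from which a direction could be read for this step.

On that basis the step from compound 2 to compound 4 in this assay is expected to be a 1.4-fold lower number from compound 2 to compound 4 (0.15 log units; within the scatter), with the direction open. Compound 4 is accordingly estimated at 6000 nM, within a range from 1500 nM to 24000 nM.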

Compound 4, concentration for 50% growth inhibition: 4300 nM
For compound 4 the middle estimate is 1.4-fold (0.14 log units) above the measured one; measured number inside the range.
By their numbers in this assay, from the lowest: compounds 1, 4, 2 and 3 (each within the scatter of the next, the first and the last beyond it).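

In this assay the change of hydrogen to phenoxymethyl on a saturated chain carbon, three bonds along the chain from an aromatic nitrogen, gives a 2.0-fold lower number from compound 2 to compound 4 (0.29 log units; within the scatter) and so stays within the usual scatter of this read-out. Going by these compounds alone, this is the first step at this position, since the earlier step concerned only a hydroxy on an aromatic carbon and the other compounds differ in several places at once. It shows that this position accepts 8 further heavy atoms, including a six-membered aromatic ring of carbon only, with no change in growth inhibition that can be told from scatter, although one step at one position supports no wider rule. No measurement at hand gives a reason for this outcome.

The compounds shown leave open whether an amine, a carboxylic acid or a plain longer chain in place of the phenoxymethyl would also leave the number within the scatter. They also leave open whether the same change would behave alike on the core of compound 1, which carries one hydroxy fewer on its aromatic ring.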